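A smaller halogenated aryl group on the sulfur bridge

The source may hold more compounds than are shown below. What is called first, only, known or untested is meant among the compounds shown, and "the series" means these compounds.

Compound 1 `Nc1cc(N)c2nc(-c3ccccc3)c(Oc3ccc(Cl)c(Cl)c3)nc2c1` gives 87100 nM in a functional assay on UACC-257 cells (Homo sapiens) for inhibition, read by sulforhodamine B assay, with a stated time of 48 h; on this read-out lower numbers stand for stronger inhibition of growth and higher numbers for weaker inhibition of growth.
Compound 2 `COc1ccc(Sc2nc3cc(N)cc(N)c3nc2-c2ccccc2)cc1` gives only a limit of the assay, < 100000 nM in this assay.
Compound 3 `Nc1cc(N)c2nc(-c3ccccc3)c(Sc3ccc(Cl)c(Cl)c3)nc2c1` gives 58900 nM in this assay.

Compound 3 and compound 1 sit close together, separated by a 1.5-fold lower number from compound 1 to compound 3 (0.17 log units; within the scatter). The value of compound 2 is a limit and sets no readable size on the steps a step that the limit leaves unreadable from compound 1 to compound 2 and a step that the limit leaves unreadable from compound 2 to compound 3 (the limit of < 100000 nM in this assay, at which 1 of the 3 values shown sits).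

Compound 4 `Nc1cc(N)c2nc(-c3ccccc3)c(Sc3ccc(F)cc3)nc2c1` differs from compound 3 in one place: 4-fluorophenyl in place of 3,4-dichlorophenyl on a sulfur. Going by the values given here, no measured step changes the aryl group on the sulfur in a readable way, since the only comparison on that sulfur, from compound 2 to compound 3, rests on a limit. Among the compounds with values here, the one readable step, from compound 1 to compound 3, changed the bridging atom and stayed within the scatter. Compound 4 is therefore expected to stay near compound 3, with a step of a 1.2-fold higher number from compound 3 to compound 4 (0.07 log units; within the scatter) in this assay that does not clearly exceed the scatter. Compound 4 is estimated at 70000 nM, in a range from 30000 nM to 160000 nM.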

Compound 4, concentration for total growth inhibition: 31600 nM
For compound 4 the middle estimate is 2.2-fold (0.35 log units) above the measured one; the range from low to high includes it.
By their numbers in this assay, from the lowest: compounds 4, 3 and 1 (each within the scatter of the next, the first and the last beyond it).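

Going by these compounds alone, the change from 3,4-dichlorophenyl to 4-fluorophenyl on a sulfur gives the first readable step on this aryl group in this assay, and that step stays within the scatter (a 1.9-fold lower number from compound 3 to compound 4 (0.27 log units; within the scatter)). Within the data shown here, putting (4-fluorophenyl)sulfanyl in place of 3,4-dichlorophenoxy on an aromatic carbon gives the first step at this position that lies beyond the scatter, though it is only a modest one (a 2.8-fold lower number from compound 1 to compound 4 (0.44 log units; beyond the scatter)). Steps that involve compound 2 cannot be read: the limit of < 100000 nM in this assay, at which 1 of the 4 values shown sits.

The compounds shown leave open whether the two chlorine atoms or the fluorine matters more for the read-out, as no single change here separates them. They also leave open how an amine or a carboxylic acid on this aryl ring, or a longer alkyl chain on the sulfur in place of the ring, would read.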